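The compounds below may be only part of what the source reports. "The series", "measured", "known", "first", "only" and "open" are said of these compounds alone.

Two compounds have so far been measured in a functional assay on A549 cells (Homo sapiens) for antiproliferative activity, read by MTT assay, with a stated time of 72 h; on this read-out higher numbers stand for weaker inhibition and lower numbers for stronger inhibition:

compound 1 `COc1cc(C(=O)c2sc3ccccc3c2-c2ccc(Cl)cc2)cc(OC)c1OC` gives 7500 nM
compound 2 `CCOc1ccc(-c2c(C(=O)c3cc(OC)c(OC)c(OC)c3)sc3ccccc23)cc1` gives 3100 nM

Compound 2 holds the lower of these two numbers, which makes it the stronger inhibitor of the pair. Within the data shown here, the only measured step is modest, a 2.4-fold lower number from compound 1 to compound 2 (0.38 log units; beyond the scatter) (ethoxy in place of chloro on an aromatic carbon).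

The next compound is compound 3 `COc1ccc(Nc2c(C(=O)c3cc(OC)c(OC)c(OC)c3)sc3ccccc23)cc1`, which alters the same large group on the shared core. The difference is (4-methoxyphenyl)amino in place of 4-ethoxyphenyl on an aromatic carbon, in words (4-methoxyphenyl)amino in place of 4-ethoxyphenyl on an aromatic carbon. Among the measured compounds shown here, no measured step covers a change of this kind, since the only one available, a 2.4-fold lower number from compound 1 to compound 2 (0.38 log units; beyond the scatter), swapped a single substituent on the outer aromatic ring. That step therefore guides the expected size only loosely and says little about direction. A modest step toward a lower number in this assay is expected, with real uncertainty on either side.

The estimated change is a 2.1-fold lower number from compound 2 to compound 3 (0.32 log units; beyond the scatter) overall. For compound 3 the expected value is 1500 nM, with an estimated range from 250 nM to 7000 nM.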

Compound 3, half-maximal inhibitory concentration: 9300 nM
For compound 3 the middle estimate is 6.2-fold (0.79 log units) below the measured one; the whole stated range lies below it.
By their numbers in this assay, from the lowest: compound 2; then compounds 1 and 3 (each within the scatter of the next).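

In this assay, the change at this ring carbon, next to the ring atom that bears a large group, gave a 3.0-fold higher number from compound 2 to compound 3 (0.48 log units; beyond the scatter). Among these compounds, this is the first sign that the group here can do more than adjust potency slightly through a substituent on its outer ring: (4-methoxyphenyl)amino, with its hydrogen-bond donor, gives up the advantage held by the directly attached 4-ethoxyphenyl group. Against the 4-chlorophenyl group, the same replacement gave a 1.2-fold higher number from compound 1 to compound 3 (0.09 log units; within the scatter), so compound 3 and compound 1 cannot be told apart in this assay, despite their different links to the core; no measurement shown explains the loss relative to compound 2.

The step from compound 2 to compound 3 changes both the link to the core and the ether on the outer ring, so the compounds shown cannot assign the higher number to either change alone. A 4-methoxyphenyl group or a (4-ethoxyphenyl)amino group at this position would separate the two, while a methylamino link would address whether the amine hydrogen matters.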